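The source may report more compounds than this note shows. Statements on the series, on what has been measured and on what is new or still open speak of the compounds shown alone.

Measured so far, all in a functional assay on HT-29 cells (Homo sapiens) for cytotoxicity, read by MTT assay, with a stated time of 72 h; a lower number here means that less compound is tolerated, a higher number that more compound is tolerated:
Compound 1 `COc1ccc(CNc2nc([SeH])nc3ccccc23)cc1` gives > 100000 nM, a limit of the assay.
Compound 2 `Sc1nc(NCc2ccccc2)c2ccccc2n1` gives > 100000 nM, likewise a limit.
Compound 3 `CSc1nc(NCCCCCO)c2cccnc2n1` gives > 100000 nM, again a limit.

Compound 2 thus stands at the same limit as every other measured compound, with no number of its own (the limit of > 100000 nM in this assay, at which 3 of the 3 values shown sit). The unmeasured compound 4 `[SeH]c1nc(NCc2ccccc2)c2ccccc2n1` differs from compound 2 by one selenium atom in place of one sulfur atom, on an aromatic carbon — one selenium atom in place of one sulfur atom, on an aromatic carbon. Going by the values given here, no step between measured compounds is at hand to scale this change. Compound 1, with its > 100000 nM at the limit, carries the same selenium group. In line with the limit of > 100000 nM in this assay, at which 3 of the 3 values shown sit, the step from compound 2 to compound 4 is expected to be none beyond the scatter, a number no higher from compound 2 to compound 4 (the limit leaves the size open). Compound 4 is estimated at 100000 nM, between 30000 nM and 300000 nM, and is expected to be reported again only as a limit.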

Compound 4, concentration lethal to 50% of the cells: > 100000 nM
Compound 4 gave a limit, no number; the forecaster's own chance of this, stated with the estimate: 85%; the middle value lies on the limit itself.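

Going by these compounds alone, compound 1, compound 2 and compound 4 all sit at a limit, so no step among them can be read: the limit of > 100000 nM in this assay, at which 4 of the 4 values shown sit. The compounds shown leave open whether one selenium atom in place of one sulfur atom, on an aromatic carbon, makes any difference to cytotoxicity.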